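A few compounds are considered here, and "the series" means these few. Any claim that something is new, unique, unknown or untested is made for them only; others in the source may bear on it.

Compound 1, with the structure `C=CC1=C(C(=O)NC2CCCCC2)C(c2ccc(OC)cc2)OC1`, and compound 2, with the structure `C=CC1=C(C(=O)NCc2ccc(Cl)cc2)C(c2ccc(OC)cc2)OC1`, share one core and differ only in the group carried on the amide nitrogen. In a functional assay on A549 cells (Homo sapiens) for cytotoxicity, read by MTT assay, with a stated time of 24 h (on this read-out higher numbers stand for weaker inhibition and lower numbers for stronger inhibition), compound 1 gives > 100000 nM, which is a limit of the assay rather than a measured number. In this assay compound 2 likewise gives > 100000 nM, again only a limit. The change a step that the two limits leave unreadable from compound 1 to compound 2 therefore cannot be sized, since both ends sit at the limit of > 100000 nM in this assay, at which 2 of the 2 values shown sit. Compound 2 thus stands at the upper edge of what this assay can report, with no number of its own.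

Compound 3, with the structure `C=CC1=C(C(=O)NCCCCC)C(c2ccc(OC)cc2)OC1`, arises from compound 2 by the change (butyl in place of 4-chlorophenyl on a saturated chain carbon bound to an amide-type nitrogen). Going by the values given here, no measured step speaks to this kind of change, as the one step in hand is unreadable. Given that compound 2 sits at a limit and that this is the only evidence, compound 3 is expected to stay at or near that limit, a change of about a step that the limit leaves unreadable from compound 2 to compound 3. The estimate for compound 3 in this assay is 150000 nM, with a range from 40000 nM to 600000 nM.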

Compound 3, half-maximal inhibitory concentration: 36500 nM
Compound 3: the middle estimate sits 4.1-fold (0.61 log units) above what was measured, outside the stated range (below it).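

Going by these compounds alone, the amide nitrogen is the first place where a change produces a measurable value: with a pentyl chain there, this assay yields a real number instead of a limit. Exchanging the 4-chlorobenzyl group for pentyl gives an at least 2.7-fold lower number from compound 2 to compound 3 (0.43 log units; beyond the scatter), and exchanging cyclohexyl for pentyl gives an at least 2.7-fold lower number from compound 1 to compound 3 (0.43 log units; beyond the scatter), so the open chain stands apart from both ring-bearing groups by more than the usual scatter. Both steps give only a minimum size, since neither starting compound has a number of its own: the limit of > 100000 nM in this assay, at which 2 of the 3 values shown sit.

The compounds shown cannot separate the loss of a ring from the particular length of the chain, as pentyl is the only open chain among them and a shorter propyl or a longer octyl chain would be needed to tell how the value follows chain length. They also leave open what a primary amine or a carboxylic acid at the end of the pentyl chain would do, and whether any such change would bring the value lower still.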